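A ring shift in the ether of a pyridone series

The compounds below may be only part of what the source reports. "The series", "measured", "known", "first", "only" and "open" are said of these compounds alone.

Three measured compounds share one core and differ only at the saturated chain carbon bound to an aromatic nitrogen. In a functional assay on CHO cells for positive allosteric modulation of metabotropic glutamate receptor 2 (Homo sapiens), read by scintillation counting and GTPgammaS binding, with a stated time of 30 min (a lower number here means that less compound is needed, a higher number that more compound is needed for the effect), compound 1 `Cc1cc(Oc2ccc(-c3ccn(CC4CCC4)c(=O)c3C#N)cc2)ccn1` gives 126 nM, compound 2 `CCCCn1ccc(-c2ccc(Oc3ccnc(C)c3)cc2)c(C#N)c1=O` gives 398 nM, and compound 3 `Cc1cc(Oc2ccc(-c3ccn(CC4CC4)c(=O)c3C#N)cc2)ccn1` gives 832 nM. Compound 3 thus stands highest of the three: the steps run a 3.2-fold higher number from compound 1 to compound 2 (0.50 log units; beyond the scatter), a 6.6-fold higher number from compound 1 to compound 3 (0.82 log units; beyond the scatter) and a 2.1-fold higher number from compound 2 to compound 3 (0.32 log units; beyond the scatter).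

Compound 4 `Cc1ccc(Oc2ccc(-c3ccn(CC4CC4)c(=O)c3C#N)cc2)c(C)n1` keeps the cyclopropylmethyl group of compound 3 and instead alters the ether: 2,6-dimethylpyridin-3-yl in place of 2-methylpyridin-4-yl on an oxygen on an aromatic ring. None of the three measured steps touches this part of the molecule; all concern the saturated chain carbon bound to the aromatic nitrogen, so none of them bears on the change from compound 3 to compound 4. With nothing measured to go on, no step beyond the scatter is expected in either direction. Compound 4 is therefore estimated at 1000 nM in this assay, within a wide range from 250 nM to 4000 nM. The step this estimate implies, a 1.2-fold higher number from compound 3 to compound 4 (0.08 log units; within the scatter), is expected to be small.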

Compound 4, half-maximal effective concentration: 263 nM
The estimate for compound 4 lay 3.8-fold (0.58 log units) above the measured number; the range from low to high includes it.
By their numbers in this assay, from the lowest: compound 1; then compounds 4 and 2 (each within the scatter of the next); then compound 3.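

Going by these compounds alone, the ether ring, which none of the earlier steps touched, proves to matter in this assay: with the cyclopropylmethyl group held constant, 2,6-dimethylpyridin-3-yl in place of 2-methylpyridin-4-yl brings a 3.2-fold lower number from compound 3 to compound 4 (0.50 log units; beyond the scatter) and so moves the number beyond the scatter. The number therefore responds to the group on the oxygen as well as to the group on the aromatic nitrogen, and here less compound is needed with the ring that has one more heavy atom. No measurement given here accounts for this step.

The single change both adds a methyl group and shifts the ring's point of attachment, so the shown compounds cannot separate the two; a 2-methylpyridin-3-yl group on the oxygen would bear on that question. On these data alone, whether the step holds with the cyclobutyl, or with the butyl chain of compound 2, also remains open.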